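A few compounds are considered here, and "the series" means these few. Any claim that something is new, unique, unknown or untested is made for them only; others in the source may bear on it.

Working notes on the series. The shared core of compound 1 `CNC(=O)/C=C/c1ccncc1-c1ccc2ccccc2c1` carries an acrylamide whose nitrogen is varied. In an assay on a protein complex for inhibition of CDK8/Cyclin C (Homo sapiens), with a stated time of 1 h, tested at 10 uM (a higher number here means more inhibition at the concentration tested (going by the name of the read-out), a lower number less inhibition), compound 1 gives 101%. Compound 2 `COC1CN(C(=O)/C=C/c2ccncc2-c2ccc3ccccc3c2)C1` gives 100% in this assay, and compound 3 `O=C(O)CCNC(=O)/C=C/c1ccncc1-c1ccc2ccccc2c1` gives 91%. On these numbers compound 3 sits within the scatter of both neighbours: the step was a number 10 percentage points lower from compound 1 to compound 3 (within the scatter) and a number 9 percentage points lower from compound 2 to compound 3 (within the scatter), so no order among the three can be read. The step of a number 1 percentage points lower from compound 1 to compound 2 (within the scatter) likewise shows that changing the group on the carbonyl carbon moved nothing beyond the scatter.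

Compound 4 `NC(=O)/C=C/c1ccncc1-c1ccc2ccccc2c1` differs from compound 3 by hydrogen in place of 2-carboxyethyl on an amide-type nitrogen. Within the data shown here, the steps that bear on it are those at the amide nitrogen, 1>3 and 2>3, and the one at the carbonyl carbon, 1>2; all were within the scatter. Removing the 2-carboxyethyl is therefore expected to give no step beyond the scatter in this assay, in either direction, the expected step being a number 6 percentage points higher from compound 3 to compound 4 (within the scatter). Compound 4 is expected to give 97% in this assay, within 86% to 104%.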

Compound 4, a percentage reported as inhibition, at one concentration (the size of the read-out at that concentration, not a potency): 102%
For compound 4 the middle estimate is 5 percentage points below the measured one; measured number inside the range.
By their numbers in this assay, from the lowest: compounds 3, 2, 1 and 4 (each within the scatter of the next, the first and the last beyond it).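

Among these compounds, at the amide-type nitrogen, taking away 2-carboxyethyl gives a number 11 percentage points higher from compound 3 to compound 4 (beyond the scatter) in this assay and is the only step beyond the scatter among the four compounds, so this position can register a change, if only a modest one. The step to the same primary amide from the 3-methoxyazetidin-1-yl amide, a number 2 percentage points higher from compound 2 to compound 4 (within the scatter) and the step from the methyl amide, a number 1 percentage points higher from compound 1 to compound 4 (within the scatter) show that neither group separates from hydrogen here, while compound 3 stays within the scatter of compound 1 and compound 2, so the gap appears only against compound 4. Nothing available explains this step.

From the compounds shown here alone, whether the step follows the carboxylic acid or the chain itself stays open. A plain propyl chain, a 2-aminoethyl chain or a longer carboxyalkyl chain on this nitrogen would separate these readings.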